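Methyl on the oxygen: expected growth inhibition for compound 3

A few compounds are considered here, and "the series" means these few. Any claim that something is new, unique, unknown or untested is made for them only; others in the source may bear on it.

compound 1 `COc1ccc(/C=C/[C@@](C)(/C=C/c2ccc(O)cc2)CCC=C(C)C)cc1`: 40%
compound 2 `CC(C)=CCCC(C)(/C=C/c1ccc(O)cc1)/C=C/c1ccc(O)cc1`: 33%
compound 3 `COc1ccc(/C=C/[C@](C)(/C=C/c2ccc(O)cc2)CCC=C(C)C)cc1`: not yet measured

Among the measured compounds shown here, in a functional assay on A549 cells (Homo sapiens) for inhibition, with a stated time of 48 h, tested at 50 uM (on this read-out higher numbers stand for more inhibition of growth at the one concentration tested and lower numbers for less inhibition of growth), compound 2 gives 33%, within the scatter of the only other measured compound, compound 1 at 40%. Compound 3 has methyl in place of hydrogen on an oxygen on an aromatic ring. For the measured compounds named here, one measured step bears on this, the reverse exchange: a number 7 percentage points lower from compound 1 to compound 2 (within the scatter). That single step gives no ground to expect a change beyond the scatter, so the expected step is small, a number 5 percentage points higher from compound 2 to compound 3 (within the scatter). For compound 3 the estimated value is 38%, with an expected range of 27% to 49%.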

Compound 3, percent growth inhibition at one concentration: 70%
Beside the measured number, compound 3's estimate is 32 percentage points below it, outside the stated range (above it).
By their numbers in this assay, from the lowest: compounds 2 and 1 (each within the scatter of the next); then compound 3.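

In this assay, methyl in place of hydrogen on the oxygen can produce a large change, a number 37 percentage points higher from compound 2 to compound 3 (beyond the scatter), so this position is not as flat as the earlier pair suggested. The gain appears only with the configuration drawn S, with the step between the two methyl compounds reading a number 30 percentage points higher from compound 1 to compound 3 (beyond the scatter). The stereocentre at the saturated chain carbon therefore decides the outcome here: the fact that compounds 1 and 3 differ only in the configuration as drawn

Still open, on these data alone, is whether an ethyl group or a longer chain on that oxygen keeps the higher number. As far as these compounds go, it is also open whether the S configuration holds its lead with such a group in place.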